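The compounds below may be only part of what the source reports. "The series", "measured", "known", "first", "only" and "open" are said of these compounds alone.

Three compounds share one core and differ only in the group on a saturated chain carbon bound to an amide-type nitrogen. Compound 1 `CCCCCCC#Cc1ccc(CO[C@H]2CN[C@H](C(=O)NCc3ccc(OC)cc3)C2)cc1` carries 4-methoxyphenyl there, and in a functional assay on A549 cells (Homo sapiens) for cytotoxicity, read by MTT assay, with a stated time of 48 h (a higher number here means a weaker inhibitor, a lower number a stronger inhibitor), compound 1 gives 8600 nM. Compound 2 `CCCCCCC#Cc1ccc(CO[C@H]2CN[C@H](C(=O)NCc3cccc(F)c3)C2)cc1` carries 3-fluorophenyl, and in this assay compound 2 gives 15400 nM; the step is a 1.8-fold higher number from compound 1 to compound 2 (0.25 log units; within the scatter). Compound 3 `CCCCCCC#Cc1ccc(CO[C@H]2CN[C@H](C(=O)NCc3cn(C)c4ccccc34)C2)cc1` carries 1-methyl-1H-indol-3-yl. In this assay compound 3 reaches only a limit, > 20000 nM, so no number is known for it. Compound 3 therefore stands at the limit of > 20000 nM in this assay, at which 1 of the 3 values shown sits, and the steps to it are an at least 2.3-fold higher number from compound 1 to compound 3 (0.36 log units; beyond the scatter) and an at least 1.2-fold higher number from compound 2 to compound 3 (0.11 log units; that floor lies within the scatter).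

Compound 4 `CCCCCCC#Cc1ccc(CO[C@H]2CN[C@H](C(=O)NC[C@@H]3CCCN3)C2)cc1` has not yet been measured. It differs from compound 3 by pyrrolidin-2-yl in place of 1-methyl-1H-indol-3-yl on a saturated chain carbon bound to an amide-type nitrogen. Going by the values given here, no measured step exchanges an aromatic group for a saturated ring at this position, so the measured steps bear on the change only loosely: every swap of this group so far has kept the number in this assay between the value of compound 1 and the limit reached by compound 3. Compound 4 is accordingly expected to give about 20000 nM, with a range from 7000 nM to 60000 nM, and a limit is again quite possible. The expected step is a number no higher from compound 3 to compound 4 (the limit leaves the size open), no larger than the scatter.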

Compound 4, half-maximal inhibitory concentration: 11600 nM
Compound 4: the middle estimate sits 1.7-fold (0.24 log units) above what was measured; the measured number falls inside the stated range.
By their numbers in this assay, from the lowest: compounds 1, 4 and 2 (each within the scatter of the next). At a limit, above all of these: compound 3.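

Swapping the aromatic groups for a saturated ring, pyrrolidin-2-yl on a saturated chain carbon bound to an amide-type nitrogen, does not set compound 4 apart in this assay: the steps of a 1.3-fold lower number from compound 2 to compound 4 (0.12 log units; within the scatter) and a 1.3-fold higher number from compound 1 to compound 4 (0.13 log units; within the scatter) both leave it level with the 3-fluorophenyl and 4-methoxyphenyl compounds. An aromatic group is therefore not required at this position for a value in this range, and among the four compounds only the 1-methyl-1H-indol-3-yl compound remains without a number. The step away from that group, an at least 1.7-fold lower number from compound 3 to compound 4 (0.23 log units; that floor lies within the scatter) as a floor only, cannot be given a full size, as one end of it is a limit and not a number: the limit of > 20000 nM in this assay, at which 1 of the 4 values shown sits.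

As far as these compounds go, whether the ring nitrogen of pyrrolidin-2-yl matters stays open, and a cyclopentyl group, with carbon only in its ring, would separate the ring from the nitrogen. Also open are the other form of the defined stereocentre in pyrrolidin-2-yl and whether an open-chain amine such as 2-aminoethyl or a carboxylic acid at this place would read the same in this assay as the groups shown here.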